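The source may hold more compounds than are shown below. What is called first, only, known or untested is meant among the compounds shown, and "the series" means these compounds.

Working notes on the series. Compound 3 `Clc1ccc(/C=N/c2sc3c(c2-c2nc4ccccc4s2)CCCC3)cc1` is the reference point for the next step. Going by the values given here, in an ADME assay on HepG2 cells (Homo sapiens) for cytotoxicity, read by MTT assay, with a stated time of 72 h (a higher number here means that more compound is tolerated, a lower number that less compound is tolerated), compound 3 gives 397 ug/mL, the highest of the three numbers measured so far; compound 1 `Fc1ccccc1/C=N/c1sc2c(c1-c1nc3ccccc3s1)CCC2` gives 394 ug/mL, which sits within the scatter of compound 3, while compound 2 `Clc1ccccc1/C=N/c1sc2c(c1-c1nc3ccccc3s1)CCC2` gives 180 ug/mL, the furthest away and beyond the scatter. Among the compounds with values here, the only measured step, a 2.2-fold lower number from compound 1 to compound 2 (0.34 log units; beyond the scatter), runs in the opposite sense to the halogen change now considered.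

Compound 4 `Fc1ccccc1/C=N/c1sc2c(c1-c1nc3ccccc3s1)CCCC2` is not yet measured. It differs from compound 3 by 2-fluorophenyl in place of 4-chlorophenyl on a carbon with a double bond to nitrogen. Within the data shown here, no measured step matches this change exactly, since the chloro-to-fluoro step of compound 1 and compound 2 sits on a different core and keeps the halogen in the same position. Compound 4 also shares its aryl group with compound 1, whose value in this assay is within the scatter of compound 3. Compound 4 is therefore expected to give 400 ug/mL, with a range from 250 ug/mL to 600 ug/mL, which means the step of a 1.0-fold higher number from compound 3 to compound 4 (0.00 log units; within the scatter) is expected to stay within the scatter.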

Compound 4, half-maximal cytotoxic concentration: 398 ug/mL
The estimate for compound 4 lay 1.0-fold (0.00 log units) above the measured number, within the range that was stated.
By their numbers in this assay, from the lowest: compound 2; then compounds 1, 3 and 4 (each within the scatter of the next).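

In this assay, going by these compounds alone, the change to 2-fluorophenyl in place of 4-chlorophenyl on a carbon with a double bond to nitrogen gives a 1.0-fold higher number from compound 3 to compound 4 (0.00 log units; within the scatter) and so stays within the scatter, whereas the only earlier step, a 2.2-fold lower number from compound 1 to compound 2 (0.34 log units; beyond the scatter) on a different core, lies beyond it. The new step alters both the halogen and its place on the phenyl ring, and this single pair cannot separate the two changes. Nothing available explains the result.

Open, from the compounds shown here alone, is how 4-fluorophenyl or 2-chlorophenyl would read on the core of compound 3, either of which would separate the halogen from its place on the ring. All groups shown here are halogen-bearing phenyl rings, leaving open whether a phenyl ring carrying an amine or a carboxylic acid would stay within the scatter of compound 3.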